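The source may report more compounds than this note shows. Statements on the series, on what has been measured and on what is new or still open speak of the compounds shown alone.

The measured compounds in a functional assay on NCI-H460 cells (Homo sapiens) for cytotoxicity, read by sulforhodamine B assay; a lower number here means a stronger inhibitor of growth, a higher number a weaker inhibitor of growth:
compound 1 `CC1=CC[C@@H]([C@@](C)(O)CCCC(C)(C)NC(=S)NN)CC1` gives 12800 nM
compound 2 `CC1=CC[C@@H]([C@@](C)(O)CCCC(C)(C)NC(=S)N/N=C\c2ccc(O)cc2)CC1` gives 1460 nM
compound 3 `CC1=CC[C@@H]([C@@](C)(O)CCCC(C)(C)NC(=S)N/N=C\c2ccc([N+](=O)[O-])cc2)CC1` gives 10100 nM

Compound 1 has the highest of the three numbers in this assay. Its number and that of compound 3 lie within the scatter of each other, while the number of compound 2 lies beyond the scatter: an 8.8-fold lower number from compound 1 to compound 2 (0.94 log units; beyond the scatter). Compound 4 `CC1=CC[C@@H]([C@@](C)(O)CCCC(C)(C)NC(=S)N/N=C\c2cccc(Cl)c2)CC1` is not yet measured. It differs from compound 1 by a group of 9 heavy atoms (7 carbon, 1 nitrogen, 1 chlorine; one six-membered aromatic ring of carbon only) in place of one nitrogen atom, on an amide-type nitrogen.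

Within the data shown here, two measured steps bear on this change. The first is the step from compound 1 to compound 2, which replaced the same nitrogen atom by a hydroxy-bearing ring group, an 8.8-fold lower number from compound 1 to compound 2 (0.94 log units; beyond the scatter). The second is the step within that ring series, nitro in place of hydroxy, a 6.9-fold higher number from compound 2 to compound 3 (0.84 log units; beyond the scatter), which took the number almost back to where compound 1 stands. The ring-bearing group therefore moves the number in either a strongly or a barely favourable direction depending on what sits on the ring; chlorine is a third, untested case. Compound 4 is thus expected to fall between compound 2 and compound 3, a modest lowering from compound 1, a 3.2-fold lower number from compound 1 to compound 4 (0.51 log units; beyond the scatter). The estimate for compound 4 is 4000 nM, with a range from 1500 nM to 12000 nM.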

Compound 4, concentration for 50% growth inhibition: 44300 nM
Compound 4: the middle estimate sits 11-fold (1.04 log units) below what was measured; the whole stated range lies below it.
By their numbers in this assay, from the lowest: compound 2; then compounds 3 and 1 (each within the scatter of the next); then compound 4.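

In this assay the 3-chlorophenyl group on the amide-type nitrogen is the only ring-bearing group shown that moves the number upward from the unsubstituted hydrazine end of compound 1 (a 3.5-fold higher number from compound 1 to compound 4 (0.54 log units; beyond the scatter)), so attaching a ring-bearing group at this place does not in itself lower the number. What the ring carries can therefore set the direction of the change as well as its size: the number also rises on going to the 3-chlorophenyl group from the 4-nitrophenyl group (a 4.4-fold higher number from compound 3 to compound 4 (0.64 log units; beyond the scatter)) and, by much more, from the 4-hydroxyphenyl group (a 30-fold higher number from compound 2 to compound 4 (1.48 log units; beyond the scatter)), the largest step among these compounds. Nothing available gives a reason for this order.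

On these data alone, the 3-chlorophenyl group differs from the 4-hydroxyphenyl and 4-nitrophenyl groups in both the substituent and where it stands on the ring, and how much of the rise belongs to each remains open. Also open, as far as these compounds go, are the number an unsubstituted phenyl group or a 3-aminophenyl group would give at this nitrogen, and whether the order seen in this assay would hold in other cells.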